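The source may report more compounds than this note shows. Statements on the series, on what has been measured and on what is new or still open speak of the compounds shown alone.

Compound 1, with the structure `Nc1scc(-c2ccccc2)c1C(=O)c1ccccc1`, was tested in a functional assay on CHO cells for agonist activity at adenosine receptor A1 (Homo sapiens), read by fluorescence and ERK phosphorylation, with stated times of 30 min and 1.5 h, tested at 10 uM (a lower number here means a weaker effect, a higher number a stronger effect of the compound at the concentration tested), where compound 1 gives 48%. Among the compounds with values here, only one other compound has been measured alongside it: compound 2, with the structure `Nc1scc(-c2cccc(F)c2)c1C(=O)c1ccccc1`, which in this assay gives 52%. The two differ only by a fluoro in place of hydrogen on an aromatic carbon, and the change in this assay is a number 4 percentage points higher from compound 1 to compound 2 (within the scatter), so compound 1 sits together with compound 2 rather than apart from it.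

Compound 3, with the structure `Nc1scc(-c2cccc(Cl)c2)c1C(=O)c1ccccc1`, has not yet been measured. Its difference from compound 1 is chloro in place of hydrogen on an aromatic carbon. Within the data shown here, the only measured step that bears on this is the one from compound 1 to compound 2, which places a different halogen on the same aromatic carbon and produced a change of a number 4 percentage points higher from compound 1 to compound 2 (within the scatter). On that basis the step from compound 1 to compound 3 is expected to be a number 4 percentage points higher from compound 1 to compound 3 (within the scatter), that is, no movement beyond the scatter in either direction. Compound 3 is therefore estimated to give 52% in this assay, with a likely range from 35% to 70%.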

Compound 3, a percentage reported as activity, at one concentration (the size of the read-out at that concentration, not a potency): 52%
Beside the measured number, compound 3's estimate shows no gap at the digits printed, within the range that was stated.
By their numbers in this assay, from the lowest: compounds 1, 2 and 3 (each within the scatter of the next).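

In this assay, placing chloro on this aromatic carbon gives a number 4 percentage points higher from compound 1 to compound 3 (within the scatter), and chloro in place of fluoro gives no change at the digits printed from compound 2 to compound 3 (within the scatter). This position, meta to a large group, now carries two different halogens, and neither one separates its compound beyond the scatter from compound 1, which has hydrogen there, or from the compound with the other halogen, so for these three compounds the choice among hydrogen, fluoro and chloro leaves the read-out within the usual spread of repeats. Nothing available here explains why these three compounds read alike.

The compounds shown contain only hydrogen and two halogens at this position, so it remains open whether a clearly different group there, such as a methoxy group, an amine or a carboxylic acid, would move the read-out beyond the scatter in either direction. Going by these compounds, it also remains open whether chloro on another carbon of the same ring would read the same way, and whether a read-out at a single concentration hides differences in potency among compounds 1, 2 and 3.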